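Swapping a Nitrile-Bearing Ring for Naphthalene on the Piperazine

The source may hold more compounds than are shown below. What is called first, only, known or untested is meant among the compounds shown, and "the series" means these compounds.

Two measured compounds set the scene. Compound 1 `COc1ccc(NC(=O)c2ccc(-c3ccc(C4=NC(C)ON4)cc3C)cc2)cc1N1CCN(C)CC1` was tested in a functional assay for agonist activity at 5-hydroxytryptamine receptor 1B (Homo sapiens), read by cAMP accumulation; a lower number here means that less compound is needed, a higher number that more compound is needed for the effect; in it compound 1 gives > 1000 nM, which is a limit of the measurement rather than a number. For compound 1 that reading is the limit of > 1000 nM in this assay, at which 1 of the 2 values shown sits. Within the data shown here, compound 2 `CN1CCN(c2cccc3ccc(OCC(=O)N4CCN(c5ccccc5C#N)CC4)cc23)CC1` gives 28 nM in this assay, the only actual number among the two results. Compound 3 `CN1CCN(c2cccc3ccc(OCC(=O)N4CCN(c5cccc6ccccc56)CC4)cc23)CC1` has not yet been measured. It differs from compound 2 in one place: naphthalen-1-yl in place of 2-cyanophenyl on an amine nitrogen in a ring. Among the measured compounds shown here, no measured pair shows what such a swap does, so the step expected in this assay is a 1.4-fold lower number from compound 2 to compound 3 (0.15 log units; within the scatter), nothing beyond the usual scatter. Compound 3 is therefore estimated at 20 nM, expected to lie between 5 nM and 100 nM.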

Compound 3, half-maximal effective concentration: > 1000 nM
Compound 3 gave a limit, no number (the forecaster's own chance of this, stated with the estimate: 5%); middle value at least 50-fold (1.69 log units) from the limit.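

In this assay, placing naphthalen-1-yl instead of 2-cyanophenyl on this amine nitrogen in a ring gives an at least 35-fold higher number from compound 2 to compound 3 (1.55 log units; beyond the scatter), so the two aromatic groups are far from interchangeable here. Compounds 1 and 2 differ in more than one place, which makes this the first step shown that ties a large change in the number to this single position. Compound 3 reads only as a limit of the assay, not as a number: the limit of > 1000 nM in this assay, at which 2 of the 3 values shown sit.

The change removes the nitrile and adds a second aromatic ring at once, and the compounds shown cannot say which of the two matters. Going by these compounds, a plain phenyl group on the same nitrogen, with no nitrile and no second ring, would help to separate them, and how it would read remains open.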